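The source may report more compounds than this note shows. Statements on the series, on what has been measured and on what is new or still open speak of the compounds shown alone.

In a functional assay on HeLa cells (Homo sapiens) for antiproliferative activity, read by MTT assay, with a stated time of 48 h (on this read-out lower numbers stand for stronger inhibition and higher numbers for weaker inhibition), compound 1 (`COc1ccc(N(C)c2ccnc(Cl)n2)cc1Cl`) gives 517 nM, compound 2 (`COc1ccc(N(C)c2ccnc(Cl)n2)cc1OCCBr`) gives 3310 nM and compound 3 (`COc1ccc(N(C)c2ccnc(Cl)n2)cc1OCCCCBr`) gives 307 nM. Compound 3 and compound 1 sit together at the low end of this small set: a 1.7-fold lower number from compound 1 to compound 3 (0.23 log units; within the scatter). Compound 2 lies clearly apart from both, with a 6.4-fold higher number from compound 1 to compound 2 (0.81 log units; beyond the scatter) and an 11-fold lower number from compound 2 to compound 3 (1.03 log units; beyond the scatter). Compound 4 (`COc1ccc(N(C)c2ccnc(Cl)n2)cc1OCCCCC[Se]C#N`) changes compound 3 at the end of its chain: a group of 4 heavy atoms (2 carbon, 1 nitrogen, 1 selenium; no ring) in place of one bromine atom, on a saturated chain carbon, four bonds along the chain from an oxygen on an aromatic ring. Going by the values given here, no measured step makes this exchange, so the only guide is the large step from compound 2 to compound 3, which shows that changes in this chain can shift the number. A modest step towards a lower number is therefore expected in this assay, though with little certainty. The estimated step is a 2.0-fold lower number from compound 3 to compound 4 (0.31 log units; beyond the scatter). For compound 4 the expected value is 150 nM, within an estimated range of 30 nM to 800 nM.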

Compound 4, half-maximal inhibitory concentration: > 10000 nM
Compound 4: only a limit was reported (the forecaster's own chance of this, stated with the estimate: 3%); at least 66-fold (1.82 log units) between middle value and limit.
By their numbers in this assay, from the lowest: compounds 3 and 1 (each within the scatter of the next); then compound 2. At a limit, above all of these: compound 4.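

In this assay, going by these compounds alone, the earlier steps only altered a chain that kept bromine at its end, whereas replacing that bromine with the group of 4 heavy atoms containing selenium gives an at least 32-fold higher number from compound 3 to compound 4 (1.51 log units; beyond the scatter). This group also carries the chain past the weakest bromine-ended compound, with an at least 3.0-fold higher number from compound 2 to compound 4 (0.48 log units; beyond the scatter). Compound 4 has only a limit rather than a number, so both steps are minimum sizes: the limit of > 10000 nM in this assay, at which 1 of the 4 values shown sits.

Which part of the entering group goes with this loss of activity remains open. So does how an amine or a plain nitrile at the chain end would read.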